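The compounds below may be only part of what the source reports. "The series", "measured", "known", "first", "only" and "open" are said of these compounds alone.

Measured in a functional assay on A549 cells (Homo sapiens) for antiproliferative activity, read by luminescence, with a stated time of 72 h; a lower number here means a stronger inhibitor, a higher number a weaker inhibitor:

- Compound 1 `CN1CC2(CC(=O)c3cc(/C=C/C(=O)NO)ccc3O2)C1`: 429 nM
- Compound 2 `O=C(/C=C/c1ccc2c(c1)C(=O)CC1(CN(Cc3ccccc3)C1)O2)NO`: 245 nM

Only these two compounds have been measured in this assay, and their values lie within the scatter of each other, so compound 2 cannot be ranked apart from compound 1. Compound 3 `O=C(/C=C/c1ccc2c(c1)C(=O)CC1(CN(Cc3ccc(F)cc3)C1)O2)NO` remains to be measured. It departs from compound 2 in one place, with fluoro in place of hydrogen on an aromatic carbon, para to a large group, which turns benzyl to 4-fluorobenzyl (fluoro in place of hydrogen on an aromatic carbon).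

Within the data shown here, no measured step shows this change directly. The closest evidence is a 1.8-fold lower number from compound 1 to compound 2 (0.24 log units; within the scatter), where phenyl replaces hydrogen on a saturated chain carbon bound to an amine nitrogen in a ring. That step concerns the same part of the molecule and stays within the scatter, but it is a different and larger change. No step beyond the scatter is therefore expected in this assay, and no direction can be favoured with confidence. The expected outcome is a 1.1-fold lower number from compound 2 to compound 3 (0.03 log units; within the scatter). For compound 3 the estimated value is 230 nM, with an expected range of 110 nM to 480 nM.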

Compound 3, half-maximal inhibitory concentration: 684 nM
For compound 3 the middle estimate is 3.0-fold (0.47 log units) below the measured one; the measured number lies above the stated range.
By their numbers in this assay, from the lowest: compounds 2, 1 and 3 (each within the scatter of the next, the first and the last beyond it).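

In this assay, fluoro in place of hydrogen on this aromatic carbon, para to a large group, gives a 2.8-fold higher number from compound 2 to compound 3 (0.45 log units; beyond the scatter), the first step among these compounds that lies beyond the scatter. The earlier pair had shown only a step within the scatter, whereas this result shows that a change of a single heavy atom on the benzyl group can separate two compounds, and here the separation runs toward a higher number. The 4-fluorobenzyl compound nevertheless cannot be ranked apart from the compound without an aromatic ring on that nitrogen, as the step reads a 1.6-fold higher number from compound 1 to compound 3 (0.20 log units; within the scatter), and no available evidence accounts for the effect of the fluoro group.

The compounds shown rest this reading on one pair, so it remains open whether the step belongs to fluoro in particular or would also appear with chloro or methoxy on the same carbon. As far as these compounds go, it is also open whether fluoro on another carbon of the six-membered aromatic ring would give a step of similar size in this assay.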